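The source may report more compounds than this note shows. Statements on the series, on what has been measured and on what is new or still open speak of the compounds shown alone.

Measured so far in a functional assay on UACC-62 cells (Homo sapiens) for cytotoxicity, read by sulforhodamine B assay; a lower number here means a stronger inhibitor of growth, a higher number a weaker inhibitor of growth

compound 1 `CC1=CC[C@@H]([C@@](C)(O)CCCC(C)(C)NC(=S)NN)CC1` gives 18500 nM
compound 2 `CC1=CC[C@@H]([C@@](C)(O)CCCC(C)(C)NC(=S)N/N=C\c2ccccc2[N+](=O)[O-])CC1` gives 6050 nM
compound 3 `CC1=CC[C@@H]([C@@](C)(O)CCCC(C)(C)NC(=S)N/N=C\c2cccc([N+](=O)[O-])c2)CC1` gives 7840 nM

Compound 3 (7840 nM) lies within the scatter of compound 2 (6050 nM), while compound 1 (18500 nM) has the higher number, beyond the scatter of both. Compound 4 `CC1=CC[C@@H]([C@@](C)(O)CCCC(C)(C)NC(=S)N/N=C\c2cccc(Cl)c2)CC1` has chloro in place of nitro on an aromatic carbon of compound 3 (chloro in place of nitro on an aromatic carbon) and awaits measurement. Among the measured compounds shown here, the only measured step (a 1.3-fold higher number from compound 2 to compound 3 (0.11 log units; within the scatter)) exchanges one nitrophenyl for another. For the measured compounds named here, no measured step replaces nitro, so that step gives only weak guidance. No step beyond the scatter is expected in this assay here. The estimated step is a 1.1-fold lower number from compound 3 to compound 4 (0.05 log units; within the scatter) on present data. Compound 4 is estimated at 7000 nM with an expected range from 3200 nM to 15000 nM in this series.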

Compound 4, concentration for 50% growth inhibition: 7810 nM
For compound 4 the middle estimate is 1.1-fold (0.05 log units) below the measured one, within the range that was stated.
By their numbers in this assay, from the lowest: compounds 2, 4 and 3 (each within the scatter of the next); then compound 1.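

In this assay, chloro and nitro on this aromatic carbon, meta to a large group, cannot be told apart (a 1.0-fold lower number from compound 3 to compound 4 (0.00 log units; within the scatter)). The 3-chlorophenyl and 2-nitrophenyl compounds also stay within the scatter of each other (a 1.3-fold higher number from compound 2 to compound 4 (0.11 log units; within the scatter)), so this small set shows no need for nitro. The step beyond the scatter is still seen with chloro in the aromatic group (a 2.4-fold lower number from compound 1 to compound 4 (0.37 log units; beyond the scatter)). On these data alone, whether an amine or a carboxylic acid on the same aromatic carbon would also stay within the scatter remains open. Nothing available accounts for the match between chloro and nitro.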